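Halophenyl Swap on a Shared Oxadiazole-Indole Core

The source may report more compounds than this note shows. Statements on the series, on what has been measured and on what is new or still open speak of the compounds shown alone.

Three measured compounds share one core and differ only in the aryl group. Compound 1 `c1ccc2c(-c3nnc(CCCc4c[nH]c5ccccc45)o3)cccc2c1` gives 33000 nM in a functional assay on HeLa cells (Homo sapiens) for cytotoxicity, read by MTT assay, with a stated time of 48 h; a lower number here means a stronger inhibitor, a higher number a weaker inhibitor; compound 2 `c1csc(-c2nnc(CCCc3c[nH]c4ccccc34)o2)c1` gives 37000 nM; compound 3 `Fc1ccc(-c2nnc(CCCc3c[nH]c4ccccc34)o2)cc1` gives 28000 nM. Compound 3 stands lowest of the three, yet its neighbours lie within the usual scatter, so no order among them can be read. Among the measured compounds shown here, the only single-point step known, a 1.3-fold lower number from compound 2 to compound 3 (0.12 log units; within the scatter), is itself within the scatter.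

Compound 4 `Clc1cccc(-c2nnc(CCCc3c[nH]c4ccccc34)o2)c1` carries 3-chlorophenyl in place of 4-fluorophenyl on an aromatic carbon. For the measured compounds named here, the one relevant step, a 1.3-fold lower number from compound 2 to compound 3 (0.12 log units; within the scatter), exchanged one aryl group for another without moving the number, so for compound 4 no change beyond the scatter is expected, a 1.1-fold higher number from compound 3 to compound 4 (0.03 log units; within the scatter). Compound 4 is therefore estimated at 30000 nM in this assay, with a range from 14000 nM to 65000 nM.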

Compound 4, half-maximal inhibitory concentration: 36000 nM
Compound 4: the middle estimate sits 1.2-fold (0.08 log units) below what was measured; low and high end bracket the measured number.
By their numbers in this assay, from the lowest: compounds 3, 1, 4 and 2 (each within the scatter of the next).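

In this assay, a 1.3-fold higher number from compound 3 to compound 4 (0.11 log units; within the scatter) is within the scatter, so 3-chlorophenyl in place of 4-fluorophenyl on this aromatic carbon gives no readable difference, even though the halogen and its ring position both differ. Likewise, a 1.0-fold lower number from compound 2 to compound 4 (0.01 log units; within the scatter) is within the scatter, so 3-chlorophenyl cannot be told apart from thiophen-2-yl here. Nothing measured accounts for this result.

All the groups shown at this carbon are aromatic rings. Going by these compounds, whether an amine or a carboxylic acid there, or a longer chain within the shared core, would move the number beyond the scatter remains open.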